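Benzotriazole carboxamide series: phenyl added on the amide substituent

A few compounds are considered here, and "the series" means these few. Any claim that something is new, unique, unknown or untested is made for them only; others in the source may bear on it.

Compound 1, `CCC(C)C(NC(=O)n1nnc2ccccc21)C(=O)NC1CCCCC1`, gives > 100000 nM in a functional assay on SW-620 cells (Homo sapiens) for inhibition; a higher number here means a weaker inhibitor, a lower number a stronger inhibitor; this is a limit of the assay.
Compound 2, `CCC(C)C(NC(=O)n1nnc2ccccc21)C(=O)NCc1ccccc1`, gives > 100000 nM in this assay; this is a limit of the assay.
Compound 3, `CC(C)C(NC(=O)NO)C(=O)NC1CCCCC1`, gives > 100000 nM in this assay; this is a limit of the assay.

Compound 2 stands at the limit of this assay, with no number of its own, and so do the two other measured compounds: every value in this set sits at the limit of > 100000 nM in this assay, at which 3 of the 3 values shown sit. Among the measured compounds shown here, the only one-place step among them, a step that the two limits leave unreadable from compound 1 to compound 2, is therefore unreadable, both limits hiding whatever change the benzyl in place of cyclohexyl on an amide-type nitrogen may have brought. Compound 3 shares no single-point change with compound 2 and adds nothing readable.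

Compound 4, `CCC(C)C(NC(=O)n1nnc2ccccc21)C(=O)NC(c1ccccc1)c1ccccc1`, differs from compound 2 by phenyl in place of hydrogen on a saturated chain carbon bound to an amide-type nitrogen and an aromatic carbon. For the measured compounds named here, no measured step bears on this change, since the one step available carries no size. With compound 2 at the limit and no readable step in the set, the expectation for compound 4 is that it also sits at or near the limit, with no step beyond the scatter discernible. For compound 4 the expected step is a step that the limit leaves unreadable from compound 2 to compound 4. Compound 4 is estimated at 150000 nM, within 30000 nM to 600000 nM.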

Compound 4, half-maximal inhibitory concentration: 63500 nM
Compound 4: the middle estimate sits 2.4-fold (0.37 log units) above what was measured; the range from low to high includes it.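

Phenyl in place of hydrogen on a saturated chain carbon bound to an amide-type nitrogen and an aromatic carbon gives the only value in this set that is a number, with compound 4 at 63500 nM in this assay. From the compounds shown here alone, the reading is an at least 1.5-fold lower number from compound 2 to compound 4 (0.19 log units; that floor lies within the scatter); as this floor is set by a limit, the true size of the step stays unknown, and the change cannot yet be said to exceed the usual scatter. This position is therefore the only place in the series where a change has brought a compound off the assay limit, which the other compounds do not reach: the limit of > 100000 nM in this assay, at which 3 of the 4 values shown sit.

Going by these compounds, it remains open whether the second phenyl ring itself matters at this carbon, or whether a methyl or a cyclohexyl on the same carbon would also give a value that is a number. Also open, on these data alone, is how the series responds to a further change on the phenyl rings of compound 4, such as an amine or a carboxylic acid, and whether any such change would give a step clearly beyond the scatter.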